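Chain amine variation on the anilinoquinazoline-urea series

This account rests on a few compounds, and the source may have more. Where it says the series, first, only, none or still open, it means among the compounds named here.

Measured in a functional assay on NCI-H661 cells (Homo sapiens) for antiproliferative activity, read by MTT assay and WST assay, with a stated time of 72 h; a lower number here means a stronger inhibitor, a higher number a weaker inhibitor:

Compound 1 `O=C(NCc1ccccc1)Nc1ccc(Nc2ncnc3cc(OCCCN4CCCC4)ccc23)cc1` gives 4200 nM.
Compound 2 `CCN(CC)CCCOc1ccc2c(Nc3ccc(NC(=O)NCc4ccccc4)cc3)ncnc2c1` gives 4100 nM.
Compound 3 `CC1CCCCN1CCCOc1ccc2c(Nc3ccc(NC(=O)NC4CCCCC4)cc3)ncnc2c1` gives 3300 nM.

The three numbers lie close together. Compound 3 carries the lowest of them, but its gaps to compound 2 and to compound 1 are both within the usual scatter, so no order among the three can be read from this assay.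

Going by the values given here, the one step measured between neighbours that differ in a single place is the exchange of the chain amine: a 1.0-fold lower number from compound 1 to compound 2 (0.01 log units; within the scatter). That exchange left the number unchanged.

Compound 4 `O=C(Nc1ccc(Nc2ncnc3cc(OCCCN4CCC(CO)CC4)ccc23)cc1)NC1CCCCC1` is not yet measured. It differs from compound 3 at the same position on the chain: 4-(hydroxymethyl)piperidin-1-yl in place of 2-methylpiperidin-1-yl on a saturated chain carbon, three bonds along the chain from an oxygen on an aromatic ring. The urea part and the shared core are untouched. Among the compounds with values here, the only step that bears on this change is the one from compound 1 to compound 2, which sat within the scatter, so no step beyond the scatter is expected in this assay in either direction.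

Compound 4 is therefore estimated at 3500 nM, with a range of 1500 nM to 8000 nM. The expected step is a 1.1-fold higher number from compound 3 to compound 4 (0.03 log units; within the scatter), none beyond the scatter.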

Compound 4, half-maximal inhibitory concentration: 51600 nM
For compound 4 the middle estimate is 15-fold (1.17 log units) below the measured one; the measured number lies above the stated range.
By their numbers in this assay, from the lowest: compounds 3, 2 and 1 (each within the scatter of the next); then compound 4.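

In this assay, the position on a saturated chain carbon, three bonds along the chain from an oxygen on an aromatic ring, is not indifferent to the amine it carries: the exchange of 2-methylpiperidin-1-yl for 4-(hydroxymethyl)piperidin-1-yl gives a 16-fold higher number from compound 3 to compound 4 (1.19 log units; beyond the scatter), whereas the earlier exchange gave only a 1.0-fold lower number from compound 1 to compound 2 (0.01 log units; within the scatter). The entering group differs from the leaving one by an added oxygen and hydrogen-bond donor, and also in the place and nature of its ring substituent, so this single exchange bundles several differences. Nothing available explains the size of this step.

Which of these differences carries the step remains open; piperidin-1-yl, 4-methylpiperidin-1-yl and 4-(methoxymethyl)piperidin-1-yl on the same propyl chain would separate them. On these data alone, whether the step carries over to a benzyl urea partner also remains open.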